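Working notes: tert-butyl in place of trifluoromethyl

This account rests on a few compounds, and the source may have more. Where it says the series, first, only, none or still open, it means among the compounds named here.

Values in an ADME assay on Raji cells (Homo sapiens) for cytotoxicity, with a stated time of 72 h (on this read-out lower numbers stand for an effect already at smaller amounts and higher numbers for an effect only at larger amounts of compound), for the measured compounds:
Compound 1 (`CCc1ccc(NC(=O)Nc2cc(C)nc3ccccc23)cc1`) reads > 25000 nM as a limit.
Compound 2 (`Cc1cc(NC(=O)Nc2cccc(C(F)(F)F)c2)c2ccccc2n1`) reads 10000 nM as a number.
Compound 3 (`Cc1cc(NC(=O)Nc2ccc([N+](=O)[O-])c(C(F)(F)F)c2)c2ccccc2n1`) reads > 25000 nM as a limit.

Going by the values given here, compound 2 holds 10000 nM as the only true number of the three. The remaining readings sit at the limit of > 25000 nM in this assay, at which 2 of the 3 values shown sit, and are limits.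

Compound 4 (`Cc1cc(NC(=O)Nc2cccc(C(C)(C)C)c2)c2ccccc2n1`) is the next to be read. It differs from compound 2 by tert-butyl in place of trifluoromethyl on an aromatic carbon with tert-butyl in place of trifluoromethyl on an aromatic carbon, meta to a large group.

Among the compounds with values here, only one measured step starts from compound 2: an at least 2.5-fold higher number from compound 2 to compound 3 (0.39 log units; beyond the scatter) for nitro in place of hydrogen on an aromatic carbon. Within the data shown here, that step keeps trifluoromethyl, and no measured step exchanges this group, so it bears only weakly on the new change.

In this assay no step beyond the scatter is expected on this thin basis, and any drift is expected toward a higher number. The expected step is a 1.4-fold higher number from compound 2 to compound 4 (0.15 log units; within the scatter) in this estimate. Compound 4 is estimated at 14000 nM with an expected range of 5000 nM to 35000 nM for the reading.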

Compound 4, half-maximal effective concentration: > 25000 nM
Compound 4 gave a limit, no number; the forecaster's own chance of this, stated with the estimate: 35%; middle value at least 1.7-fold (0.25 log units) from the limit.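

In this assay, going by these compounds alone, tert-butyl in place of trifluoromethyl is the first measured exchange of this group itself, and it gives an at least 2.5-fold higher number from compound 2 to compound 4 (0.39 log units; beyond the scatter). The reading therefore responds to what sits at this place, on an aromatic carbon meta to a large group, and not only to the added nitro of an at least 2.5-fold higher number from compound 2 to compound 3 (0.39 log units; beyond the scatter). The reading of compound 4 is a limit, not a number, so the full size of the step cannot be read, and compound 4 joins the compounds at that limit: the limit of > 25000 nM in this assay, at which 3 of the 4 values shown sit.

Within the data shown here, compound 2 remains the only compound with a true number, and the order among compound 1, compound 3 and compound 4 stays open. Also open, from the compounds shown here alone, is whether an amine or a carboxylic acid in place of trifluoromethyl at this position would keep a number like that of compound 2 or also reach the limit.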